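This account rests on a few compounds, and the source may have more. Where it says the series, first, only, none or still open, it means among the compounds named here.

Compound 2 `CN(CC1=CC[C@H]2C[C@@H]1C2(C)C)Cc1ccc(-c2cccc([N+](=O)[O-])c2)cc1` is the point of departure. Among the compounds with values here, in an assay on HEK293 cells for displacement of a labelled ligand from C-X-C chemokine receptor type 3 (Homo sapiens) (a lower number here means a stronger inhibitor, a higher number a weaker inhibitor), compound 2 gives 2000 nM, and this is the only number in the set. The related compound 1 `Cc1cccc(-c2ccc(CN(C)CC3=CC[C@H]4C[C@@H]3C4(C)C)cc2)c1` gives in this assay only a limit, > 316 nM. The step that the limit leaves unreadable from compound 1 to compound 2 therefore cannot be read, because of the limit of > 316 nM in this assay, at which 1 of the 2 values shown sits.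

The next compound is compound 3 `CN(CC1=CC[C@H]2C[C@@H]1C2(C)C)Cc1ccc(-c2cc(Cl)cc(Cl)c2)cc1`, which differs from compound 2 by 3,5-dichlorophenyl in place of 3-nitrophenyl on an aromatic carbon. Within the data shown here, no measured step bears directly on this exchange: the single step recorded, from a methyl to a nitro group on the same aromatic carbon, is unreadable, and no other pair of compounds in the set touches that ring. The expectation for compound 3 thus rests on the value of compound 2 alone, with wide uncertainty in either direction.

On that basis compound 3 is expected to give about 1200 nM in this assay, within a range of 200 nM to 6000 nM. The step of a 1.7-fold lower number from compound 2 to compound 3 (0.22 log units; within the scatter) is accordingly expected to stay within the scatter of repeated measurements.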

Compound 3, inhibition constant: > 316 nM
Compound 3: no number, only a limit; the forecaster's own chance of this, stated with the estimate: 30%; the middle value does not contradict the limit.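

In this assay compound 3 gives only a limit, > 316 nM. No step from compound 3 to compound 1 or compound 2 can be read, because of this: the limit of > 316 nM in this assay, at which 2 of the 3 values shown sit.

The compounds shown leave open how 3-methylphenyl, 3-nitrophenyl and 3,5-dichlorophenyl rank against one another in this assay.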